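A few compounds are considered here, and "the series" means these few. Any claim that something is new, unique, unknown or untested is made for them only; others in the source may bear on it.

Values so far in a functional assay on NCI-H1975 cells (Homo sapiens) for antiproliferative activity (on this read-out higher numbers stand for weaker inhibition and lower numbers for stronger inhibition), are these
- compound 1 `CC(=O)N1CCCc2c(C)c3c(n2-c2ccc(C(N)=O)c(c2)N[C@@H](C)[C@@H]1C)CC(C)(C)CC3=O` gives 20 nM
- compound 2 `CC(=O)N1CCc2c(C)c3c(n2-c2ccc(C(N)=O)c(c2)N[C@@H](C)[C@H](C)C1)CC(C)(C)CC3=O` gives 15 nM
- compound 3 `COCCC(=O)N1CCCc2c(C)c3c(n2-c2ccc(C(N)=O)c(c2)N[C@@H](C)[C@@H]1C)CC(C)(C)CC3=O` gives 37 nM

Compound 2, at 15 nM, lies within the scatter of compound 1, at 20 nM, so the two cannot be ranked. Compound 3, at 37 nM, gives a higher number than compound 2, and that gap lies beyond the scatter.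

Compound 4 `CC[C@H](N)C(=O)N1CCc2c(C)c3c(n2-c2ccc(C(N)=O)c(c2)N[C@@H](C)[C@H](C)C1)CC(C)(C)CC3=O` keeps the core of compound 2 and carries 1-aminopropyl in place of methyl on a carbonyl carbon, which reads as acetyl to (1-aminopropyl)carbonyl (1-aminopropyl in place of methyl on a carbonyl carbon). Among the measured compounds shown here, one measured step bears on this change, since it also lengthens the chain on that carbonyl: a 1.9-fold higher number from compound 1 to compound 3 (0.27 log units; within the scatter). It is only a loose guide, as it was measured on the core of compound 1 rather than that of compound 2. For the measured compounds named here, no measured compound carries an amino group on this chain, so the data cannot show how that group will read out.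

In this assay a similarly modest shift towards a higher number is therefore expected, with no change beyond the scatter as the likeliest outcome. The expected step is a 1.9-fold higher number from compound 2 to compound 4 (0.27 log units; within the scatter), and it is only an estimate. For compound 4 the estimated value is 28 nM, with an expected range from 9 nM to 90 nM.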

Compound 4, half-maximal inhibitory concentration: 41 nM
Beside the measured number, compound 4's estimate is 1.5-fold (0.17 log units) below it; low and high end bracket the measured number.
By their numbers in this assay, from the lowest: compounds 2, 1, 3 and 4 (each within the scatter of the next, the first and the last beyond it).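

In this assay, 1-aminopropyl in place of methyl on the carbonyl carbon gives a 2.7-fold higher number from compound 2 to compound 4 (0.44 log units; beyond the scatter), so a change at this position now lies beyond the scatter. Among the compounds shown here, the only earlier step here, a 1.9-fold higher number from compound 1 to compound 3 (0.27 log units; within the scatter), stayed within the scatter, but it was measured on the core of compound 1 and brought no amine, so it could not show what this amine-bearing chain does on the core of compound 2. The step is modest, and compound 4, at 41 nM, stays in the same range as compound 3 on the printed numbers, yet no measurement shown here explains the shift.

The compounds shown leave open whether the amine or the added carbon chain sets this step, a question that a plain propyl group on the same carbonyl carbon would help to separate. Also open, on these data alone, is how a carboxylic acid in place of the amine, or 1-aminopropyl on the core of compound 1, would read out in this assay.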